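Adding a bromine to a Bile Acid Receptor Agonist Core

The source may hold more compounds than are shown below. What is called first, only, known or untested is meant among the compounds shown, and "the series" means these compounds.

Of the compounds shown here, three sharing one core have been measured. In an assay on HeLa cells for agonist activity at Bile acid receptor (Homo sapiens), read by a luciferase reporter, with a stated time of 24 h (on this read-out lower numbers stand for an effect already at smaller amounts and higher numbers for an effect only at larger amounts of compound), compound 1 `c1ccc(-c2noc(-c3ccccc3)n2)cc1` gives 530 nM. Compound 2 `COc1ccc(-c2nc(-c3cccc(C(F)(F)F)c3)no2)cc1` gives 2900 nM in this assay, and compound 3 `COc1ccc(-c2nc(-c3ccccc3C)no2)cc1` gives 120 nM. Compound 1 therefore holds the second highest of the three numbers: compound 3 stands at a lower number, beyond the scatter, while compound 2 stands at a higher number, also beyond the scatter.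

Compound 4 `Brc1ccc(-c2nc(-c3ccccc3)no2)cc1` differs from compound 1 in one place: bromo in place of hydrogen on an aromatic carbon. Among the compounds with values here, no pair of measured compounds differs by this change alone, so no measured step can be carried over; compound 2 and compound 3 each combine a substituent on that ring with a second change, and their numbers cannot be split apart. For the step from compound 1 to compound 4, a small lowering of the number or no change beyond the scatter is expected, given as a 1.5-fold lower number from compound 1 to compound 4 (0.18 log units; within the scatter). Compound 4 is estimated at 350 nM, with a range from 100 nM to 1500 nM.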

Compound 4, half-maximal effective concentration: 350 nM
Estimate against measurement, compound 4: no gap at the digits printed; low and high end bracket the measured number.
By their numbers in this assay, from the lowest: compound 3; then compounds 4 and 1 (each within the scatter of the next); then compound 2.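

Swapping hydrogen for bromo on a six-membered aromatic ring of carbon only, para to a large group, gives in this assay a 1.5-fold lower number from compound 1 to compound 4 (0.18 log units; within the scatter). Within the data shown here, this is the first step on the shared core that changes one place only, and it shows that this position accepts a single bromine atom with no shift that can be told from the scatter. No measured information is at hand that would explain this result.

The compounds shown leave open how other groups at this same position, such as an amine, a carboxylic acid or a longer chain, would affect the number. They also leave open whether a bromo group on the other six-membered aromatic ring would give a similar result.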